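Carboxy for Cyanomethyl on the Amide Side Chain

A few compounds are considered here, and "the series" means these few. Any claim that something is new, unique, unknown or untested is made for them only; others in the source may bear on it.

Compound 1, `CCn1c(C(=O)NCCN(C)C)ccc1C(CC)(CC)c1ccc(OCC(O)C(C)(C)C)c(C)c1`, 14 nM in an assay on HL-60 cells for agonist activity at vitamin D3 receptor (Homo sapiens), read by microscopy, with a stated time of 96 h; on this read-out lower numbers stand for an effect already at smaller amounts and higher numbers for an effect only at larger amounts of compound
Compound 2, `CCn1c(C(=O)N(C)CCC#N)ccc1C(CC)(CC)c1ccc(OCC(O)C(C)(C)C)c(C)c1`, 1960 nM in this assay

Among the compounds with values here, compound 2 has the higher of the two numbers in this assay; the only step measured, a 140-fold higher number from compound 1 to compound 2 (2.15 log units; beyond the scatter), was a large one. Compound 3, `CCn1c(C(=O)N(C)CC(=O)O)ccc1C(CC)(CC)c1ccc(OCC(O)C(C)(C)C)c(C)c1`, differs from compound 2 by carboxy in place of cyanomethyl on a saturated chain carbon bound to an amide-type nitrogen. That earlier step bears on it, since it too altered the group on the amide-type nitrogen, but it offers no direct guide for a carboxy group. The estimate therefore stays near compound 2: compound 3 is expected to show 2500 nM, within 500 nM to 12000 nM, a step of a 1.3-fold higher number from compound 2 to compound 3 (0.11 log units; within the scatter).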

Compound 3, half-maximal effective concentration: 740 nM
Beside the measured number, compound 3's estimate is 3.4-fold (0.53 log units) above it, within the range that was stated.
By their numbers in this assay, from the lowest: compound 1; then compound 3; then compound 2.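

Replacing cyanomethyl with carboxy on the saturated chain carbon bound to the amide-type nitrogen gave, in this assay, a 2.6-fold lower number from compound 2 to compound 3 (0.42 log units; beyond the scatter), a modest step showing that this position responds to the group at the end of the chain. The carboxy compound still falls well short of the amine-bearing side chain, with a 53-fold higher number from compound 1 to compound 3 (1.72 log units; beyond the scatter), a large step. Nothing available explains either step.

The compounds shown leave open whether the amide hydrogen or the dimethylamino group accounts for the low number of compound 1. They also leave open how a longer chain ending in a carboxylic acid, or a primary amine at the chain end, would read.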